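Sulfamoyl to methylsulfonyl on the diarylamine pyrimidine series

The source may report more compounds than this note shows. Statements on the series, on what has been measured and on what is new or still open speak of the compounds shown alone.

Measured compounds:
compound 1 `Cc1ccc2nc(Nc3nc(Nc4ccc(S(C)(=O)=O)cc4)ncc3F)sc2c1` — > 50000 nM
compound 2 `NS(=O)(=O)c1ccc(Nc2ncc(F)c(Nc3nc4ccc(Cl)cc4s3)n2)cc1` — 8340 nM

Compound 1 gives only a limit in a functional assay on MCF7 cells (Homo sapiens) for antiproliferative activity, read by MTT assay, with a stated time of 48 h (a lower number here means a stronger inhibitor, a higher number a weaker inhibitor), namely > 50000 nM. Among the compounds with values here, compound 2 is the one compound of the pair with a numerical result, 8340 nM in this assay. Within the data shown here, with no measured step between compound 1 and compound 2, their values show only that one is a limit and the other a number; the two structures differ in more than one place.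

Compound 3 `CS(=O)(=O)c1ccc(Nc2ncc(F)c(Nc3nc4ccc(Cl)cc4s3)n2)cc1` is not yet measured. Relative to compound 2 it differs as methyl in place of amino on a sulfonyl sulfur. Compound 1 also carries a methylsulfonyl, and its result is the limit of > 50000 nM in this assay, at which 1 of the 2 values shown sits. Compound 3 is expected to be a weaker inhibitor than compound 2, with a step of a 3.0-fold higher number from compound 2 to compound 3 (0.48 log units; beyond the scatter) in this assay. The estimate for compound 3 in this assay is 25000 nM, within 6000 nM to 100000 nM, with a fair chance that only a limit is reported.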

Compound 3, half-maximal inhibitory concentration: > 50000 nM
Compound 3: a limit, no number (the forecaster's own chance of this, stated with the estimate: 35%); middle value at least 2.0-fold (0.30 log units) from the limit.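

In this assay, methyl in place of amino on a sulfonyl sulfur, with the rest of compound 2 unchanged, gives an at least 5.9-fold higher number from compound 2 to compound 3 (0.77 log units; beyond the scatter), so the sulfamoyl to methylsulfonyl change alone costs activity beyond the scatter. Within the data shown here, this is the first single-place reading at this sulfonyl sulfur, which compound 1 and compound 2 could not give, as they differ in more than one place. Compound 3 gives a limit and not a number, so the step has a lower bound only and its full size stays unknown, and the step from compound 1 to compound 3, chloro in place of methyl on an aromatic carbon, cannot be read: the limit of > 50000 nM in this assay, at which 2 of the 3 values shown sit.

Going by these compounds, whether a number returns with a methylamino or dimethylamino group on the sulfonyl sulfur, or with a carboxylic acid in place of the whole sulfamoyl, stays open. Also open, on these data alone, is how compound 2, at 8340 nM, responds to bromo or methoxy in place of its chloro, a change that would read on a numerical value.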